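The source may hold more compounds than are shown below. What is called first, only, known or untested is meant among the compounds shown, and "the series" means these compounds.

Of the compounds shown here, three have so far been measured in an ADME assay on HepG2 2.2.15 cells (Homo sapiens) for cytotoxicity; a lower number here means that less compound is tolerated, a higher number that more compound is tolerated. Compound 1 `CC(C)(C)OC(=O)Nc1ncc(C(Oc2ccc(Br)cc2)c2ccc(Cl)cc2)s1` gives > 50000 nM, which is a limit of the assay and not a number. Compound 2 `COc1ccc(COC(c2ccccc2)c2cnc(NC(=O)c3cccs3)s2)cc1` is recorded as "not toxic" (no number reported). Compound 3 `CCOC(=O)CCCNc1ncc(C(Oc2ccc3cc(Br)ccc3c2)c2ccc(Cl)cc2)s1` is likewise recorded as "not toxic" (no number reported), so no single number exists for it. Of the three values shown, one is a limit and two are entries without a number; the limit of > 50000 nM in this assay, at which 1 of the 3 values shown sits, shows where the limit of compound 1 sits. Compound 4 `O=S(=O)(Nc1ncc(C(Oc2ccc3cc(Br)ccc3c2)c2ccc(Cl)cc2)s1)c1ccc(Cl)cc1` differs from compound 3 on a nitrogen on an aromatic ring: (4-chlorophenyl)sulfonyl in place of 3-(ethoxycarbonyl)propyl on a nitrogen on an aromatic ring. Among the compounds with values here, no step between measured compounds is available, so nothing shows how such a change shifts this assay; since every value so far shows no toxicity, no shift beyond the scatter is expected. Compound 4 is therefore estimated at about 50000 nM, within a range from 20000 nM to 100000 nM.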

Compound 4, half-maximal cytotoxic concentration: "not toxic" (no number reported)
Nothing numeric was reported for compound 4; no gap can be computed for the estimate.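

Compound 3 and compound 4 are both recorded as not toxic without a number, so no step between them can be read, and nothing shown explains this result. The compounds shown leave open how any change of group shifts the values in this assay, as none of them has a single number.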